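Aryl swaps on the shared core: microsomal half-life notes

The compounds below may be only part of what the source reports. "The series", "measured", "known", "first", "only" and "open" are said of these compounds alone.

Compound 1, `Nc1nc(NCCNc2ncc(-c3ncc[nH]3)c(-c3ccccc3Br)n2)ccc1[N+](=O)[O-]`, in an ADME assay on microsomes from liver (Rattus norvegicus) for metabolic stability (a lower number here means that the compound disappears faster, a higher number that the compound lasts longer), gives > 0.5 h, a limit of the assay.
Compound 2, `Nc1nc(NCCNc2ncc(-c3ncc[nH]3)c(-c3cc(F)ccc3F)n2)ccc1[N+](=O)[O-]`, in this assay gives > 0.5 h, a limit of the assay.
Compound 3, `Nc1nc(NCCNc2ncc(-c3ncc[nH]3)c(-c3ccc(Cl)cc3Br)n2)ccc1[N+](=O)[O-]`, in this assay gives > 0.5 h, a limit of the assay.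

Compound 2 therefore stands on a limit only, and the two further values shown are limits as well; every measured value sits at the limit of > 0.5 h in this assay, at which 3 of the 3 values shown sit. The steps among the measured compounds cannot be sized: a step that the two limits leave unreadable from compound 1 to compound 2, a step that the two limits leave unreadable from compound 1 to compound 3 and a step that the two limits leave unreadable from compound 2 to compound 3. Whatever the exchange of the aryl group did, the assay did not resolve it.

Compound 4, `Cc1ccc(-c2nc(NCCNc3ccc([N+](=O)[O-])c(N)n3)ncc2-c2ncc[nH]2)c(Br)c1`, differs from compound 2 as follows: 2-bromo-4-methylphenyl in place of 2,5-difluorophenyl on an aromatic carbon. The step bearing on it most directly is a step that the two limits leave unreadable from compound 2 to compound 3, an aryl swap of the same kind, and it is unreadable; the same holds for a step that the two limits leave unreadable from compound 1 to compound 2. Among the compounds with values here, no step among the measured compounds gives a direction or size, so no change beyond the scatter is expected, only that compound 4 is expected to land where the others do.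

The estimate for compound 4 in this assay is 1.5 h, in a range of 0.5 h to 5 h. The step this estimate means is a step that the limit leaves unreadable from compound 2 to compound 4, and it is expected to read as a limit again.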

Compound 4, half-life: > 0.5 h
Compound 4 was reported as a limit; the forecaster's own chance of this, stated with the estimate: 80%; the middle value does not contradict the limit.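

Compound 4 also stands on a limit in this assay and not on a number, so none of its steps from compound 1, compound 2 or compound 3 can be read: the limit of > 0.5 h in this assay, at which 4 of the 4 values shown sit.

The compounds shown leave open how the four aryl groups on the shared core compare in this assay once real half-lives are read rather than limits.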